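A Sulfonamide Swap on an Inactive Triazole Series

A few compounds are considered here, and "the series" means these few. Any claim that something is new, unique, unknown or untested is made for them only; others in the source may bear on it.

In a functional assay on HCT-116 cells (Homo sapiens) for antiproliferative activity, read by MTT assay, with a stated time of 72 h (on this read-out lower numbers stand for stronger inhibition and higher numbers for weaker inhibition), compound 2 `COc1ccccc1-c1cn(C[C@H](O)[C@H]2OC(=O)C(OCc3ccccc3)=C2OCc2ccccc2)nn1` gives only the assay limit of > 100000 nM, not a number. Its two companions sit at the same point. Compound 1 `CCCCCc1ccc(-c2cn(C/C=C3\OC(=O)C(OCc4ccccc4)=C3OCc3ccccc3)nn2)cc1`, which bears a 4-pentylphenyl group, reaches only the limit of > 100000 nM in this assay. Compound 3 `COc1ccccc1-c1cn(C/C=C2\OC(=O)C(OCc3ccccc3)=C2OCc2ccccc2)nn1` likewise reaches only the limit of > 100000 nM. Among the compounds with values here, the one step among them, a step that the two limits leave unreadable from compound 1 to compound 3, cannot be read because the limit of > 100000 nM in this assay, at which 3 of the 3 values shown sit, bounds both of its ends.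

Compound 4 `Cc1ccc(S(=O)(=O)NCc2cn(C[C@H](O)[C@H]3OC(=O)C(OCc4ccccc4)=C3OCc3ccccc3)nn2)cc1` differs from compound 2 in one place: (((4-methylphenyl)sulfonyl)amino)methyl in place of 2-methoxyphenyl on an aromatic carbon. Within the data shown here, no measured step bears on this change, since every value is a limit and none can be sized. The step of a number no higher from compound 2 to compound 4 (the limit leaves the size open) is therefore expected to show nothing beyond the scatter that these data could reveal, and the estimate stays at the limit. Compound 4 is accordingly expected to give about 100000 nM in this assay, within a range of 30000 nM to 300000 nM, most probably reported once more only as a limit.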

Compound 4, half-maximal inhibitory concentration: 13100 nM
Compound 4: middle estimate off by 7.6-fold (0.88 log units), on the high side; measured number below the stated range.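

In this assay, compound 4 gives 13100 nM, the only value among the compounds shown that is a number rather than a limit. This shows that the aromatic carbon of the five-membered ring responds to a change of substituent: replacing 2-methoxyphenyl with (((4-methylphenyl)sulfonyl)amino)methyl gives an at least 7.6-fold lower number from compound 2 to compound 4 (0.88 log units; beyond the scatter). The printed size is only a minimum, because compound 2 stands at a limit and not at a number: the limit of > 100000 nM in this assay, at which 3 of the 4 values shown sit.

The compounds shown leave open which part of the entering group matters, and a plain aminomethyl group or a carboxylic acid at this carbon would help to separate those parts. They also leave open whether the same group would lower the number on the core of compound 3, which lacks the hydroxyl-bearing chain of compound 4.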